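The compounds below may be only part of what the source reports. "The series", "measured", "known", "first", "only" and "open" are said of these compounds alone.

Compound 1 `CCCCCCCCCCCCCCNC(=O)[C@H](CO)/N=C/c1ccc(OC)cc1` is one of three closely related amides that share a long saturated chain and a serine-derived core, and in a functional assay on cells (Homo sapiens) for cytotoxicity, read by MTT assay, with a stated time of 24 h (on this read-out higher numbers stand for weaker inhibition and lower numbers for stronger inhibition), compound 1 gives 28100 nM. Among the compounds with values here, that is the highest of the three values measured so far. Compound 2 `CCCCCCCCCCCCCCNC(=O)[C@H](CO)/N=C/c1ccccc1O` gives 19000 nM, and the step of a 1.5-fold lower number from compound 1 to compound 2 (0.17 log units; within the scatter) is too small to read anything into. Compound 3 `CCCCCCCCCCCCCCNC(=O)[C@H](CO)/N=C/c1ccccc1` gives 7670 nM; here the step of a 3.7-fold lower number from compound 1 to compound 3 (0.56 log units; beyond the scatter) is clearer, as is a 2.5-fold lower number from compound 2 to compound 3 (0.39 log units; beyond the scatter).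

Compound 4 `CCCCCCCCCCCCCCNC(=O)[C@H](CO)NCc1ccccc1Cl` has not yet been tested. Relative to compound 1 it carries a group of 9 heavy atoms (7 carbon, 1 nitrogen, 1 chlorine; one six-membered aromatic ring of carbon only) in place of a group of 10 heavy atoms (8 carbon, 1 nitrogen, 1 oxygen; one six-membered aromatic ring of carbon only), on a saturated chain carbon bound to a carbonyl carbon and a saturated chain carbon. Within the data shown here, none of the measured steps matches this change: the three measured compounds all keep the double bond to nitrogen and differ only on the aromatic ring, whereas compound 4 replaces the whole group and has no such double bond. The only lead is that removing the methoxy from compound 1 gave a 3.7-fold lower number from compound 1 to compound 3 (0.56 log units; beyond the scatter), so a modestly lower number is the more likely direction, with wide uncertainty.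

For compound 4 the expected step is a 2.8-fold lower number from compound 1 to compound 4 (0.45 log units; beyond the scatter). The estimated value for compound 4 is 10000 nM, with a range from 3000 nM to 30000 nM.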

Compound 4, half-maximal inhibitory concentration: 43700 nM
For compound 4 the middle estimate is 4.4-fold (0.64 log units) below the measured one; measured number outside the range, above it.
By their numbers in this assay, from the lowest: compound 3; then compounds 2, 1 and 4 (each within the scatter of the next, the first and the last beyond it).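

Within the data shown here, compound 4 is the only compound here without the double bond to nitrogen, and its (2-chlorobenzyl)amino group brings a hydrogen-bond donor that the group in compound 1 lacks; in this assay this exchange, on a saturated chain carbon bound to a carbonyl carbon and a saturated chain carbon, gives a 1.6-fold higher number from compound 1 to compound 4 (0.19 log units; within the scatter) and so makes no readable difference. The other two comparisons do separate: there is a 2.3-fold higher number from compound 2 to compound 4 (0.36 log units; beyond the scatter) and also a 5.7-fold higher number from compound 3 to compound 4 (0.76 log units; beyond the scatter) and this last step means that a change at this position does not by itself bring the lower number seen for compound 3, which remains the strongest of the four. No measurement shown here accounts for these numbers.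

The change in compound 4 combines the loss of the double bond with the arrival of a chlorine, and the compounds shown cannot tell these two apart. A benzylamino group carrying no chlorine, set against compound 3, would isolate the effect of the double bond, while a chlorine-bearing ring that keeps the double bond would isolate the effect of the chlorine.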